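Acetoxy on a level cytotoxicity series

This account rests on a few compounds, and the source may have more. Where it says the series, first, only, none or still open, it means among the compounds named here.

In an ADME assay on HEK293 cells (Homo sapiens) for cytotoxicity, read by CellTiter-Glo, with a stated time of 72 h (a lower number here means that less compound is needed, a higher number that more compound is needed for the effect), compound 1 `C=C1/C=C/C(C)(C)CC2=C(C)C(=O)[C@]3(C[C@@H](C)C=C3/C=C\1C)O2` gives 26000 nM as its reading, compound 2 `CC1=C2CC(C)(C)/C=C/C/C(C)=C\C3=C[C@H](C)C[C@]3(O2)C1=O` gives 26000 nM and compound 3 `CC1=C2CC(C)(C)/C=C/C(=O)/C(C)=C\C3=C[C@H](C)C[C@]3(O2)[C@@]1(O)C#N` gives 26000 nM as its reading too. Compound 2 therefore stands level with both others, and the three show no spread at all.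

Compound 4 `CC(=O)O[C@@H]1/C=C/C(C)(C)CC2=C(C)C(=O)[C@]3(C[C@@H](C)C=C3/C=C\1C)O2` differs from compound 2 by acetoxy in place of hydrogen on a saturated ring carbon with the acetoxy in place of hydrogen on a saturated ring carbon, next to the ring atom that bears a methyl group. Among the measured compounds shown here, no measured pair isolates a single change, so there is no direct precedent for this step.

The expectation rests only on the level readings, with compound 1 at 26000 nM and compound 3 at 26000 nM matching compound 2. No change beyond the scatter is expected in this assay, with only a slight lean towards a lower number. The estimated step of a 1.2-fold lower number from compound 2 to compound 4 (0.07 log units; within the scatter) stays within the scatter. Compound 4 is estimated at 22000 nM (10000 nM to 40000 nM).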

Compound 4, half-maximal effective concentration: 26000 nM
Estimate against measurement, compound 4: 1.2-fold (0.07 log units) below; measured number inside the range.
By their numbers in this assay, from the lowest: compounds 1, 2, 3 and 4 (each within the scatter of the next).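

In this assay, among the compounds shown here, acetoxy in place of hydrogen on a saturated ring carbon gives no change at the digits printed from compound 2 to compound 4 (within the scatter), and this is the only step that isolates a change in one place. For the compounds shown here, the position, next to the ring atom that bears a methyl group, thus takes an acetoxy group of 4 heavy atoms with no reading beyond the scatter, something the earlier compounds, which offered no such pair, could not show. No data on hand give a reason for this outcome.

Still open, going by these compounds, is whether the reading in this assay would hold with another group at this saturated ring carbon, such as a free hydroxyl, an amine, a carboxylic acid or a longer chain. A single step also leaves open whether the opposite configuration at this carbon would read the same.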